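This account rests on a few compounds, and the source may have more. Where it says the series, first, only, none or still open, it means among the compounds named here.

Measured compounds:
Compound 1, `COc1ccc(-c2[nH]c3ccccc3c2/C=C(\C#N)S(=O)(=O)c2ccccc2)cc1`, gives 2300 nM in a functional assay on HOP-92 cells (Homo sapiens) for inhibition, read by sulforhodamine B assay, with a stated time of 48 h; on this read-out lower numbers stand for stronger inhibition of growth and higher numbers for weaker inhibition of growth.
Compound 2, `COc1ccc2[nH]c(-c3ccccc3)c(C=C(C#N)C#N)c2c1`, gives 2400 nM in this assay.
Compound 3, `CCOC(=O)C(=Cc1c(-c2ccccc2)[nH]c2ccccc12)C(=O)OCC`, gives 8800 nM in this assay.

In this assay compound 1 and compound 2 sit within the scatter of each other, so no order between them is claimed; compound 3 sits beyond the scatter from compound 1, with the higher number.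

Compound 4, `COc1ccc(-c2[nH]c3ccc(OC)cc3c2/C=C(\C#N)S(=O)(=O)c2ccccc2)cc1`, is not yet measured. It differs from compound 1 by methoxy in place of hydrogen on an aromatic carbon. Going by the values given here, no step between measured compounds isolates this change. Compound 2 also carries a methoxy on its core and gives 2400 nM, close to compound 1, which suggests the change may matter little, though compound 2 differs elsewhere as well. The step from compound 1 to compound 4 in this assay is expected to be a 1.1-fold higher number from compound 1 to compound 4 (0.04 log units; within the scatter), within the scatter. Compound 4 is therefore estimated at 2500 nM, in the range 1000 nM to 6000 nM.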

Compound 4, concentration for 50% growth inhibition: 698 nM
Compound 4: middle estimate off by 3.6-fold (0.55 log units), on the high side; the whole stated range lies above it.
By their numbers in this assay, from the lowest: compound 4; then compounds 1 and 2 (each within the scatter of the next); then compound 3.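

In this assay, going by these compounds alone, methoxy in place of hydrogen on this aromatic carbon gives a 3.3-fold lower number from compound 1 to compound 4 (0.52 log units; beyond the scatter) and is the first single-place change, which the earlier compounds could not isolate. The position therefore accepts methoxy with stronger growth inhibition, shown so far only on the core of compound 1. Nothing measured on these compounds accounts for the step.

On these data alone, whether a hydroxyl, an amine or a longer ethoxy chain at this carbon would give a similar step remains open. So does whether methoxy has the same effect alongside the other side chains of compound 2 and compound 3.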